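The source may hold more compounds than are shown below. What is called first, only, known or untested is meant among the compounds shown, and "the series" means these compounds.

Compound 1 `CC(=O)N1N=C(c2ccc3ccccc3c2)OC1c1ccccc1Cl` is one of three compounds compared in a functional assay on MCF7 cells (Homo sapiens) for antiproliferative activity, read by MTT assay, with a stated time of 48 h (a higher number here means a weaker inhibitor, a lower number a stronger inhibitor), where compound 1 gives 2.36 ug/mL. Compound 2 `CC(=O)N1N=C(c2ccc3ccccc3c2)OC1c1ccc(Cl)cc1` gives 2.63 ug/mL, and compound 3 `CC(=O)N1N=C(c2ccc3ccccc3c2)OC1c1cccnc1` gives 2.61 ug/mL. Compound 1 has the lowest of these three numbers, yet every gap between them lies within the scatter, so no ordering can be read from them. Compound 4 `CC(=O)N1N=C(c2ccc3ccccc3c2)OC1c1ccncc1` has not yet been measured. Its change from compound 1 is pyridin-4-yl in place of 2-chlorophenyl on a saturated ring carbon. The measured steps that bear on this are a 1.1-fold higher number from compound 1 to compound 3 (0.04 log units; within the scatter) and a 1.1-fold higher number from compound 1 to compound 2 (0.05 log units; within the scatter), both within the scatter. A step of similar size, with no direction beyond the scatter, is therefore expected in this assay. Compound 4 is expected to give 2.5 ug/mL, between 1.5 ug/mL and 4.2 ug/mL. For compound 4 this means an expected step of a 1.1-fold higher number from compound 1 to compound 4 (0.03 log units; within the scatter).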

Compound 4, half-maximal inhibitory concentration: 2.56 ug/mL
For compound 4 the middle estimate is 1.0-fold (0.01 log units) below the measured one; low and high end bracket the measured number.
By their numbers in this assay, from the lowest: compounds 1, 4, 3 and 2 (each within the scatter of the next).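

In this assay, pyridin-4-yl on the saturated ring carbon adds a fourth group to the comparison, and all three new steps lie within the scatter: a 1.1-fold higher number from compound 1 to compound 4 (0.04 log units; within the scatter), a 1.0-fold lower number from compound 3 to compound 4 (0.01 log units; within the scatter) and a 1.0-fold lower number from compound 2 to compound 4 (0.01 log units; within the scatter). Across these four compounds, then, neither the pyridine nitrogen's placement nor swapping chlorophenyl for pyridine separates the numbers. No measurement given here explains this. As far as these compounds go, whether an aminomethyl group, a carboxylic acid or a longer alkyl chain at this carbon would shift the number remains open. So does the effect of replacing the acetyl group that all four share.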